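Working notes: dimethylamino to methoxy

The source may report more compounds than this note shows. Statements on the series, on what has been measured and on what is new or still open speak of the compounds shown alone.

Values so far in an ADME assay on HPLF cells (Homo sapiens) for cytotoxicity, with a stated time of 24 h (on this read-out lower numbers stand for higher toxicity in this test and higher numbers for lower toxicity in this test), are these.
- compound 1 `O=C1/C(=C/c2ccccc2)CCC/C1=C\c1cccc([N+](=O)[O-])c1` gives 18000 nM
- compound 2 `O=C1/C(=C/c2ccc(Cl)cc2)CCC/C1=C\c1cccc([N+](=O)[O-])c1` gives 38000 nM
- compound 3 `CN(C)c1ccc(/C=C2\CCC/C(=C\c3cccc([N+](=O)[O-])c3)C2=O)cc1` gives > 400000 nM as a limit

Among the compounds with values here, compound 3 stands at a limit and not at a number, with the limit of > 400000 nM in this assay, at which 1 of the 3 values shown sits, as its only reading. Its steps from the other two compounds are both beyond the scatter.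

Compound 4 `COc1ccc(/C=C2\CCC/C(=C\c3cccc([N+](=O)[O-])c3)C2=O)cc1` carries methoxy in place of dimethylamino on an aromatic carbon, para to a large group (methoxy in place of dimethylamino on an aromatic carbon). Within the data shown here, no measured compound carries methoxy, so only indirect steps bear on this change. Dimethylamino in place of hydrogen gave an at least 22-fold higher number from compound 1 to compound 3 (1.34 log units; beyond the scatter) and dimethylamino in place of chloro gave an at least 10-fold higher number from compound 2 to compound 3 (1.02 log units; beyond the scatter), both large. Chloro in place of hydrogen gave only a 2.1-fold higher number from compound 1 to compound 2 (0.32 log units; beyond the scatter), a modest step. Among the measured compounds shown here, compound 3, reached through an at least 10-fold higher number from compound 2 to compound 3 (1.02 log units; beyond the scatter), is the only compound with dimethylamino and the only one at the limit, so removing that group is expected to bring the number down towards those of compound 1 and compound 2. A large step to a lower number is therefore expected, estimated as an at least 6.6-fold lower number from compound 3 to compound 4 (0.82 log units; beyond the scatter) in this assay. In this assay the estimate for compound 4 is 60000 nM, with the value expected between 20000 nM and 250000 nM.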

Compound 4, half-maximal cytotoxic concentration: 354000 nM
Compound 4: the middle estimate sits 5.9-fold (0.77 log units) below what was measured, and the stated range ends below it.
By their numbers in this assay, from the lowest: compound 1; then compound 2; then compound 4. At a limit, above all of these: compound 3.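

In this assay, methoxy in place of dimethylamino gives an at least 1.1-fold lower number from compound 3 to compound 4 (0.05 log units; that floor lies within the scatter), methoxy at this place on the aromatic ring gives a 20-fold higher number from compound 1 to compound 4 (1.29 log units; beyond the scatter), and in place of chloro it gives a 9.3-fold higher number from compound 2 to compound 4 (0.97 log units; beyond the scatter). A large rise over the unsubstituted compound is therefore not confined to dimethylamino, while chloro remains the smaller change, with a 2.1-fold higher number from compound 1 to compound 2 (0.32 log units; beyond the scatter). Compound 3 stands at a limit, so the step from dimethylamino to methoxy is only a floor and not a size, and whether methoxy matches dimethylamino or falls short of it stays undecided: the limit of > 400000 nM in this assay, at which 1 of the 4 values shown sits.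

As far as these compounds go, whether a hydroxyl, an ethoxy or a primary amine at this place gives numbers close to that of compound 4 or close to those of compound 1 and compound 2 remains open. The compounds shown also leave open whether methoxy and dimethylamino have the same effect when the nitro group on the other aromatic ring is replaced by another group, such as a nitrile.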